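Aryl on the Pyrazole Nitrogen: Methyl to Methoxyphenyl

The source may report more compounds than this note shows. Statements on the series, on what has been measured and on what is new or still open speak of the compounds shown alone.

Measured compounds:
compound 1 `Cc1ccc(-n2cc(NC(=O)c3cccc(NS(=O)(=O)c4ccc(Cl)cc4)c3)cn2)cc1` gives 1080 nM in a functional assay on MCF7 cells (Homo sapiens) for inhibition, read by MTT assay, with a stated time of 48 h; a higher number here means a weaker inhibitor, a lower number a stronger inhibitor
compound 2 `COc1cccc(-n2cc(NC(=O)c3cccc(NS(=O)(=O)c4ccc(Cl)cc4)c3)cn2)c1` gives 9430 nM in this assay
compound 3 `Cn1cc(NC(=O)c2ccc(NS(=O)(=O)c3ccccc3)cc2)cn1` gives 58700 nM in this assay

Compound 3 gives the highest number of the three in this assay. It is weaker than compound 2 by a margin beyond the scatter, and further still from compound 1. Compound 4 `COc1ccc(-n2cc(NC(=O)c3ccc(NS(=O)(=O)c4ccccc4)cc3)cn2)cc1` is the unmeasured member of the set. Its structure differs from compound 3 in one place: 4-methoxyphenyl in place of methyl on an aromatic nitrogen.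

Going by the values given here, no measured step is the same change. Among the compounds with values here, the one step that touches the same position is an 8.7-fold higher number from compound 1 to compound 2 (0.94 log units; beyond the scatter), which shows that the identity of the aryl group on that nitrogen shifts the number well beyond the scatter. Compounds 1 and 2, which both carry an aryl group there, sit far lower than compound 3, but they also differ from compound 3 elsewhere, so that comparison is only indirect. Taken together, the change is expected to lower the number, and the step of a 7.3-fold lower number from compound 3 to compound 4 (0.87 log units; beyond the scatter) is the expected size. Compound 4 is therefore estimated at 8000 nM in this assay, with a range of 1500 nM to 40000 nM.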

Compound 4, half-maximal inhibitory concentration: 25600 nM
Estimate against measurement, compound 4: 3.2-fold (0.51 log units) below; measured number inside the range.
By their numbers in this assay, from the lowest: compound 1; then compound 2; then compound 4; then compound 3.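

Compound 3 and compound 4 give the first direct view of what an aryl group contributes on this aromatic nitrogen, since they differ only in that place. In this assay, the step is a 2.3-fold lower number from compound 3 to compound 4 (0.36 log units; beyond the scatter), so on this core 4-methoxyphenyl gives a lower number than methyl, a modest change but one that lies beyond the scatter, whereas the earlier step, an 8.7-fold higher number from compound 1 to compound 2 (0.94 log units; beyond the scatter), only compared one aryl group with another on a different core. No measurement at hand accounts for this step or says what the added ring does.

Compound 4 differs from compound 1 and compound 2 in more than one place, so the compounds shown leave open how much of the distance between their numbers belongs to the group on the nitrogen and how much to the rest of the structure. They also leave open how the number would respond to a benzyl group, an ethyl group or an unsubstituted phenyl on that nitrogen, and whether a 4-methylphenyl group there would give a lower number than 4-methoxyphenyl on the core of compound 4.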